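Changing the aromatic nitrogen group: compound 3 to compound 4

The compounds below may be only part of what the source reports. "The series", "measured", "known", "first", "only" and "open" are said of these compounds alone.

Measured in a functional assay on HCT-116 cells (Homo sapiens) for inhibition, read by MTT assay, with a stated time of 72 h; a higher number here means a weaker inhibitor of growth, a lower number a stronger inhibitor of growth:
compound 1 `O=C1COc2ccc(-n3cc(C[C@H](O)COCCOC[C@@H](O)Cc4ccc(-c5ccccc5)cc4)nn3)cc2N1` gives 42500 nM
compound 2 `O[C@H](COCCOC[C@@H](O)Cc1cn(Cc2ccc(Oc3ccccc3)cc2)nn1)Cc1ccc(-c2ccccc2)cc1` gives 3400 nM
compound 3 `O[C@H](COCCOC[C@@H](O)Cc1cn(-c2cccnc2)nn1)Cc1ccc(-c2ccccc2)cc1` gives 46800 nM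

Compound 3 at 46800 nM sits level with compound 1, while compound 2 at 3400 nM lies well lower. Going to compound 4 `O[C@H](COCCOC[C@@H](O)Cc1cn(Cc2ccc(C(F)(F)F)cc2)nn1)Cc1ccc(-c2ccccc2)cc1` puts 4-(trifluoromethyl)benzyl in place of pyridin-3-yl on an aromatic nitrogen with the rest unchanged. Among the compounds with values here, the one measured step at this nitrogen (a 1.1-fold higher number from compound 1 to compound 3 (0.04 log units; within the scatter)) stays within the scatter, but it involves no benzyl group. Within the data shown here, compound 2 (3400 nM) is the only measured compound with a substituted benzyl there, so it is the closer guide, though a single one. The step expected is a 7.8-fold lower number from compound 3 to compound 4 (0.89 log units; beyond the scatter) towards stronger inhibition of growth, beyond the scatter. Compound 4 is estimated at 6000 nM (expected range 2200 nM to 20000 nM) on this read-out.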

Compound 4, concentration for 50% growth inhibition: 2500 nM
Estimate against measurement, compound 4: 2.4-fold (0.38 log units) above; the range from low to high includes it.
By their numbers in this assay, from the lowest: compounds 4 and 2 (each within the scatter of the next); then compounds 1 and 3 (each within the scatter of the next).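

At this aromatic nitrogen, 4-(trifluoromethyl)benzyl in place of pyridin-3-yl brings a large change (a 19-fold lower number from compound 3 to compound 4 (1.27 log units; beyond the scatter)), and the change from the group on compound 1 is of similar size (a 17-fold lower number from compound 1 to compound 4 (1.23 log units; beyond the scatter)). Trifluoromethyl in place of phenoxy on an aromatic carbon leaves the number level (a 1.4-fold lower number from compound 2 to compound 4 (0.13 log units; within the scatter)), so compounds 2 and 4, with their two different substituted benzyl groups, both lie well below compounds 1 and 3. Nothing available explains these steps.

Still open, on these data alone, is whether a plain benzyl group, or a benzyl group carrying an amine or a carboxylic acid, would hold this level. As far as these compounds go, the effect of a longer chain at this nitrogen is also open.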